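Fluoro Gives Way to Isopropyl on the Aromatic Ring

This account rests on a few compounds, and the source may have more. Where it says the series, first, only, none or still open, it means among the compounds named here.

Of the compounds shown here, three built on a shared core have been tested in a functional assay on the whole organism for inhibition, with Rattus norvegicus as the target; on this read-out higher numbers stand for an effect only at larger amounts of compound and lower numbers for an effect already at smaller amounts. Compound 1 `CC1CC/C(=N\Nc2ccccc2)c2ncc(CC(=O)O)c(=O)n21` gives 100 umol/kg, compound 2 `CC1CCC(=NNc2ccccc2)c2ncc(C(=O)O)c(=O)n21` gives 0.6 umol/kg, and compound 3 `CC1CC/C(=N\Nc2ccc(F)cc2)c2ncc(C(=O)O)c(=O)n21` gives 12.2 umol/kg. Compound 3 thus holds the second highest of the three numbers: compound 1 sits nearer to it, with a higher number, while compound 2 lies much further off with a lower number, and both gaps are beyond the scatter.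

Compound 4 `CC(C)c1ccc(N/N=C2\CCC(C)n3c2ncc(C(=O)O)c3=O)cc1` differs from compound 3 by isopropyl in place of fluoro on an aromatic carbon. Among the compounds with values here, no pair of measured compounds shows what this single swap does, so the direction rests on little. In this assay a step of a 1.6-fold higher number from compound 3 to compound 4 (0.21 log units; within the scatter) is expected, a modest rise in the number or none beyond the scatter. Compound 4 is estimated at 20 umol/kg, within 4 umol/kg to 100 umol/kg.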

Compound 4, dose for 50% inhibition: 2.4 umol/kg
Estimate against measurement, compound 4: 8.3-fold (0.92 log units) above, and the stated range ends above it.
By their numbers in this assay, from the lowest: compound 2; then compound 4; then compound 3; then compound 1.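

Placing isopropyl where fluoro stood gives, in this assay, a 5.1-fold lower number from compound 3 to compound 4 (0.71 log units; beyond the scatter), so less compound is needed for the same effect. Within the data shown here, this is the first single change measured at this aromatic carbon, para to a large group, and it shows that a group of 3 heavy atoms can replace one of 1 heavy atom here without losing effect. No measurement available here explains why the number falls. From the compounds shown here alone, whether methoxy, chloro or a longer chain such as butyl would lower the number further remains open.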